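This account rests on a few compounds, and the source may have more. Where it says the series, first, only, none or still open, it means among the compounds named here.

The three measured compounds share one core and differ only in the group carried on the sulfur. Compound 1 `Nc1ccccc1NC(=O)/C=C/c1ccc(CSc2ccc(Cl)cc2)cc1` gives 15.2% in a functional assay on SMMC-7721 cells (Homo sapiens) for inhibition, read by CCK-8 assay, with a stated time of 72 h, tested at 2 uM; on this read-out lower numbers stand for less inhibition of growth and higher numbers for more inhibition of growth at the one concentration tested. Compound 2 `Cc1cc(C)cc(SCc2ccc(/C=C/C(=O)Nc3ccccc3N)cc2)c1` gives 8.61% in this assay, and compound 3 `CC(C)(C)c1ccc(SCc2ccc(/C=C/C(=O)Nc3ccccc3N)cc2)cc1` gives 18.3% in this assay. Compound 3 thus holds the highest of the three numbers, yet its steps to the other two stay within the scatter: a number 3.1 percentage points higher from compound 1 to compound 3 (within the scatter) and a number 9.7 percentage points higher from compound 2 to compound 3 (within the scatter). The remaining step, a number 6.6 percentage points lower from compound 1 to compound 2 (within the scatter), is also within the scatter.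

Compound 4 `Nc1ccccc1NC(=O)/C=C/c1ccc(CSc2ccc(C(F)(F)F)cn2)cc1` has not yet been measured. Its change is 5-(trifluoromethyl)pyridin-2-yl in place of 4-(tert-butyl)phenyl on a sulfur. For the measured compounds named here, every measured step altered the group on the sulfur, and none of them moved the number beyond the scatter; no measured step introduces a pyridin-2-yl or a trifluoromethyl, so the comparison rests on that general picture alone. Compound 4 is therefore expected to show a number 4.3 percentage points lower from compound 3 to compound 4 (within the scatter), a step within the scatter. For compound 4 the estimated value is 14%, with a range from 4% to 26%.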

Compound 4, percent growth inhibition at one concentration: 12.1%
The estimate for compound 4 lay 1.9 percentage points above the measured number, and the stated range covers the measured number.
By their numbers in this assay, from the lowest: compounds 2, 4, 1 and 3 (each within the scatter of the next).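

For the compounds shown here, with 5-(trifluoromethyl)pyridin-2-yl, the group on the sulfur carries a ring hetero atom and a hydrogen-bond acceptor for the first time, yet in this assay all three steps to the carbon-only rings remain within the scatter: a number 6.2 percentage points lower from compound 3 to compound 4 (within the scatter), a number 3.5 percentage points higher from compound 2 to compound 4 (within the scatter) and a number 3.1 percentage points lower from compound 1 to compound 4 (within the scatter). The earlier compounds shown here showed this only for exchanges among substituted phenyl groups, whereas compound 4 extends it to this change of ring at the same place, on a sulfur bonded to a saturated chain carbon. Nothing available bears on this result.

As far as these compounds go, it remains open whether a ring carrying an amine or a carboxylic acid would give a step beyond the scatter. The same question stands for a saturated cyclohexyl group on the sulfur.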